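Reshaping the propargylamine tail of a thiourea series

The compounds below may be only part of what the source reports. "The series", "measured", "known", "first", "only" and "open" are said of these compounds alone.

Compound 1 `C#CCN(C)Cc1cn(-c2cc(NC(=S)NCC)ncn2)cn1` gives 20.2% in an assay on isolated protein for inhibition of Amine oxidase [flavin-containing] A (Homo sapiens), read by fluorescence and Amplex Red, with a stated time of 15 min, tested at 50 uM; on this read-out lower numbers stand for less inhibition and higher numbers for more inhibition at the one concentration tested (going by the name of the read-out).
Compound 2 `C#CCN(CCCC)Cc1cn(-c2cc(NC(=S)NCC)ncn2)cn1` gives 2.43% in this assay.
Compound 3 `C#CCN1CCN(Cc2cn(-c3cc(NC(=S)NCC)ncn3)cn2)CC1` gives 9.22% in this assay.

All three compounds share one core and differ only in the amine that carries the propargyl group. Compound 3 holds the second highest of the three numbers. Its nearest neighbour is compound 2, and the step between them, a number 6.8 percentage points higher from compound 2 to compound 3 (within the scatter), stays inside the usual scatter of this kind of measurement. Its furthest neighbour is compound 1, and the step of a number 11 percentage points lower from compound 1 to compound 3 (beyond the scatter) lies beyond that scatter. Among the compounds with values here, the one other measured step, a number 17.8 percentage points lower from compound 1 to compound 2 (beyond the scatter), shows that putting propyl in place of hydrogen on the chain carbon bound to the amine nitrogen also lowers the number.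

Compound 4 `C#CCNCCCc1cn(-c2cc(NC(=S)NCC)ncn2)cn1` has not been measured yet. It differs from compound 3 by 2-(propargylamino)ethyl in place of 4-propargylpiperazin-1-yl on a saturated chain carbon bound to an aromatic carbon. Within the data shown here, no measured pair here opens the piperazine ring into a chain, so the measured steps bear on this change only loosely: the two steps that leave the core and alter the amine, from compound 1, were both modest, and one was within scatter. A step of similar, modest size, or none beyond the scatter, is therefore expected in this assay, with the direction uncertain. The estimated step is a number 2.8 percentage points higher from compound 3 to compound 4 (within the scatter), so compound 4 is expected to give about 12%, between 0% and 30%.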

Compound 4, a percentage reported as inhibition, at one concentration (the size of the read-out at that concentration, not a potency): 31.4%
For compound 4 the middle estimate is 19.4 percentage points below the measured one; the whole stated range lies below it.
By their numbers in this assay, from the lowest: compounds 2 and 3 (each within the scatter of the next); then compound 1; then compound 4.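

Replacing the ring with an open chain gives a number 22.2 percentage points higher from compound 3 to compound 4 (beyond the scatter) in this assay, so this position responds to the shape of the amine tail and not only to added bulk. Within the data shown here, the same 2-(propargylamino)ethyl group also gives a number 29 percentage points higher from compound 2 to compound 4 (beyond the scatter) and a number 11.2 percentage points higher from compound 1 to compound 4 (beyond the scatter), making it the first change in this set to raise the number above that of compound 1, whereas the changes to compound 2 and compound 3 both lowered it. It is also the only tail of the four with a hydrogen-bond donor, but it differs from the others in more than that one feature, so this comparison cannot single out which difference matters.

Nothing available here gives a measured reason for the rise. The compounds shown leave open whether the hydrogen on the amine nitrogen or the chain itself carries the gain, which a methyl group on that nitrogen of the same chain, or a longer chain with the propargylamine at its end, would help to separate.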